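Trading a Benzyloxy Group for Methylsulfanyl on the Ring

The source may report more compounds than this note shows. Statements on the series, on what has been measured and on what is new or still open speak of the compounds shown alone.

Measured in a functional assay on DU-145 cells (Homo sapiens) for inhibition, read by trypan blue exclusion, with a stated time of 96 h; on this read-out higher numbers stand for weaker inhibition of growth and lower numbers for stronger inhibition of growth:
compound 1 `O=C(/C(=C\c1ccc(OCc2ccccc2)cc1)SCc1ccc(Cl)cc1)c1ccc(Cl)cc1` gives 1000 nM
compound 2 `O=C(/C(=C\c1ccc(OCc2ccccc2)cc1)S(=O)(=O)Cc1ccc(Cl)cc1)c1ccc(Cl)cc1` gives 1000 nM

Compound 1 stands level with compound 2 at the digits shown; the two values lie within the usual scatter of each other. For the measured compounds named here, the one measured step, no change at the digits printed from compound 1 to compound 2 (within the scatter), concerns a change on the double-bonded chain carbon and leaves the aromatic rings untouched, so it gives no guidance for a change on a ring.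

Compound 3 `CSc1ccc(/C=C(/SCc2ccc(Cl)cc2)C(=O)c2ccc(Cl)cc2)cc1` differs from compound 1 in one place: methylsulfanyl in place of benzyloxy on an aromatic carbon. Going by the values given here, no measured pair shows what this change does, so the data give no direction for it. The step is therefore expected to be no change at the digits printed from compound 1 to compound 3 (within the scatter), none beyond the scatter, with a wide margin of doubt on either side.

Compound 3 is expected to give about 1000 nM in this assay, estimated to fall between 250 nM and 4000 nM.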

Compound 3, concentration for 50% growth inhibition: 25000 nM
For compound 3 the middle estimate is 25-fold (1.40 log units) below the measured one, outside the stated range (above it).
By their numbers in this assay, from the lowest: compounds 1 and 2 (each within the scatter of the next); then compound 3.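

In this assay, the swap of benzyloxy for methylsulfanyl gives a 25-fold higher number from compound 1 to compound 3 (1.40 log units; beyond the scatter), so growth inhibition becomes much weaker. For the compounds shown here, this is the first measured change on an aromatic ring, and it shows that the group on this aromatic carbon matters, whereas the change on the chain in no change at the digits printed from compound 1 to compound 2 (within the scatter) left the number within the scatter. The departing group carries a six-membered aromatic ring and the entering one has no ring, but no measurement presented here explains the loss.

Going by these compounds, it remains open whether the ring, the oxygen or the sulfur of these groups accounts for the difference, a question that methoxy or benzylsulfanyl on the same aromatic carbon could help separate. On these data alone, it is also open whether a sulfonyl in place of the sulfanyl would leave the number of compound 3 unchanged, as it did for compound 1.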